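A few compounds are considered here, and "the series" means these few. Any claim that something is new, unique, unknown or untested is made for them only; others in the source may bear on it.

Measured so far:
- compound 2, `N#Cc1ccc(C(=O)Nc2cccc(NC(=O)COc3ccc4c(=O)ccoc4c3)c2)cc1`: 123 nM
- compound 1, `CC(=O)c1ccc(OCC(=O)Nc2cccc(NC(=O)c3ccc(N(C)C)cc3)c2)cc1F`: 445 nM

Among the measured compounds shown here, only two compounds carry numbers in an assay on isolated protein for inhibition of Rho-associated protein kinase 1 (Homo sapiens), read by scintillation counting, radiometric assay and 33P incorporation, with a stated time of 40 min, in the presence of a further agent that is not named here; on this read-out lower numbers stand for stronger inhibition and higher numbers for weaker inhibition. Compound 2 stands lowest of the two; the nearest is compound 1, whose number is higher by a margin that lies beyond the usual scatter, so the order of the pair can be taken as real. For the measured compounds named here, the two compounds differ in several places at once, and no single-point step between measured compounds is available, so nothing so far isolates any one change.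

Compound 3, `NCc1ccc(C(=O)Nc2cccc(NC(=O)COc3ccc4c(=O)ccoc4c3)c2)cc1`, has not yet been measured in this assay. It is built on compound 2 and differs from it in one place:

aminomethyl in place of cyano on an aromatic carbon

Going by the values given here, no measured pair carries this same change, so its size and direction cannot be read from the data. The step expected in this assay is a 1.2-fold higher number from compound 2 to compound 3 (0.09 log units; within the scatter), a modest one whose direction is uncertain, likely within or only slightly beyond the scatter. For compound 3 the number in this assay is estimated at 150 nM, with a range from 40 nM to 600 nM.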

Compound 3, half-maximal inhibitory concentration: 532 nM
The estimate for compound 3 lay 3.5-fold (0.55 log units) below the measured number; measured number inside the range.
By their numbers in this assay, from the lowest: compound 2; then compounds 1 and 3 (each within the scatter of the next).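

In this assay, among the compounds shown here, the exchange of cyano for aminomethyl on the aromatic carbon para to a large group gives a 4.3-fold higher number from compound 2 to compound 3 (0.64 log units; beyond the scatter) and provides the first single-place comparison, showing that the number at this position responds to the group carried there and that cyano gives the lower number of the two. The two groups have the same count of heavy atoms, one carbon and one nitrogen each, so the step arises without a change in that count; the counted differences are the triple bond that leaves and the hydrogen-bond donor that enters. No measurement available here accounts for the step.

One pair cannot separate the contribution of the amine from that of the methylene link, and hydroxymethyl, dimethylaminomethyl, aminoethyl or a carboxylic acid at the same position would help to make that distinction. For the compounds shown here, it also remains open whether the same exchange gives a step of similar size and direction on a different ether-linked group, such as the one carried by compound 1.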